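The source may hold more compounds than are shown below. What is called first, only, known or untested is meant among the compounds shown, and "the series" means these compounds.

Compound 1 `C=CCn1c(SCC(=O)Nc2ccc(/C(C)=N/O)cc2)nnc1-c1ccccc1` gives 63% in a functional assay on the whole organism (strain albino) for inhibition, with Rattus norvegicus as the target, read by paw edema, with stated times of 30 min and 2 h, at a dose of 0.28 mmol/kg by the oral route; on this read-out higher numbers stand for more inhibition at the one dose given (going by the name of the read-out) and lower numbers for less inhibition.
Compound 2 `C/C(=N\O)c1ccc(NC(=O)CSc2nnc(-c3ccccc3)n2-c2ccccc2)cc1` gives 52% in this assay.
Compound 3 `COc1cc(-c2nnc(SCC(=O)Nc3ccc(C(C)=O)cc3)n2-c2ccccc2)cc(OC)c1OC` gives 54% in this assay.

Compound 1 and compound 2 share one core and differ in one place: allyl in place of phenyl on an aromatic nitrogen. That change gave a number 11 percentage points higher from compound 2 to compound 1 (beyond the scatter). Compound 3 carries a different core, and the difference between the two cores is not broken down here; its value and that of compound 2 lie within the scatter of each other, while compound 1 stands at the higher end of the three.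

Compound 4 `C=CCn1c(SCC(=O)Nc2ccc(C(C)=O)cc2)nnc1-c1cc(OC)c(OC)c(OC)c1` has not yet been measured in this assay. It differs from compound 3 by allyl in place of phenyl on an aromatic nitrogen. This is the same kind of change as that from compound 2 to compound 1, though the surroundings differ: the ring atom bears a phenyl group in compound 2 and a 3,4,5-trimethoxyphenyl group in compound 3.

Because compound 2 to compound 1 showed a number 11 percentage points higher from compound 2 to compound 1 (beyond the scatter), a step of similar direction is expected for compound 4, estimated as a number 8 percentage points higher from compound 3 to compound 4 (within the scatter). Compound 4 is therefore expected to give about 62% in this assay, most likely between 48% and 74%.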

Compound 4, a percentage reported as inhibition, in the whole organism at one dose (the size of the read-out at that dose, not a potency): 54%
For compound 4 the middle estimate is 8 percentage points above the measured one; the measured number falls inside the stated range.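

In this assay, allyl in place of phenyl on an aromatic nitrogen gave no change at the digits printed from compound 3 to compound 4 (within the scatter). Set beside the earlier step, this result cannot be separated from it: the same change on two cores in this assay, a number 11 percentage points higher (beyond the scatter) from compound 2 to compound 1 and no change at the digits printed (within the scatter) from compound 3 to compound 4, 11 percentage points apart, within the scatter of two such steps. The clear rise seen on the core of compound 1 was therefore not repeated on the core of compound 4, yet these numbers do not show that the change acts differently on the two cores, and with one pair per core they do not show that it carries over either.

The compounds shown leave open whether a propyl group, a longer chain or a chain ending in an amine on that aromatic nitrogen would read like allyl. They also leave open which of the differences between the two cores, the 3,4,5-trimethoxyphenyl group among them, has any bearing on the size of the step.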